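The source may hold more compounds than are shown below. What is called first, only, known or untested is meant among the compounds shown, and "the series" means these compounds.

Compound 1, with the structure `O=C(O)c1nn(Cc2cc(Br)ccc2OCc2ccccc2)cc1Br`, carries a carboxylic acid on a five-membered ring that also bears a bromo group. In a functional assay on CHO-K1 cells for antagonist activity at prostaglandin E2 receptor EP1 subtype (Homo sapiens), read by FLIPR (a lower number here means a stronger inhibitor, a higher number a weaker inhibitor), compound 1 reaches only the limit of < 2000 nM, so no number is known for it. Compound 2, `O=C(O)c1nn(Cc2cc(Br)ccc2OCc2ccccc2)cc1Cl`, differs from compound 1 by chloro in place of bromo on an aromatic carbon. In this assay compound 2 likewise stops at the limit of < 2000 nM. The step that the two limits leave unreadable from compound 1 to compound 2 therefore cannot be read, because the limit of < 2000 nM in this assay, at which 2 of the 3 values shown sit, gives both of its ends as limits rather than numbers.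

Compound 3, `Cc1cc(C(=O)O)nn1Cc1cc(Br)ccc1OCc1cccc(Br)c1`, has a methyl group on the five-membered ring instead of a halogen, and a 3-bromobenzyl group on the ether; how its core differs from that of compound 1 is not broken down here. In this assay, among the measured compounds shown here, compound 3 gives 129 nM, the only number among the three values.

Compound 4, `Cc1cc(C(=O)O)nn1Cc1cc(Br)ccc1OCc1cccc(Cl)c1`, has not yet been measured. It differs from compound 3 by chloro in place of bromo on an aromatic carbon. This is the same kind of change as that from compound 1 to compound 2, but not the same change: there the exchange sat on a five-membered aromatic ring with 2 nitrogen, next to the ring atom that bears a carboxy group, whereas here it sits on a six-membered aromatic ring of carbon only, meta to a large group. The earlier step gives no readable size to lean on. The exchange of one halogen for another of the same kind, leaving donors, acceptors and charge unchanged, is expected to move the value little, so compound 4 is estimated at 180 nM, between 60 nM and 550 nM, a step of a 1.4-fold higher number from compound 3 to compound 4 (0.14 log units; within the scatter) that is expected to stay within the usual scatter.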

Compound 4, inhibition constant: 427 nM
Beside the measured number, compound 4's estimate is 2.4-fold (0.38 log units) below it, within the range that was stated.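

In this assay, the exchange of 3-bromobenzyl for 3-chlorobenzyl gives a 3.3-fold higher number from compound 3 to compound 4 (0.52 log units; beyond the scatter), so on the core of compound 3 this swap of one halogen for the other is a measurable change, even though the counts of donors, acceptors and charge stay the same. Among the compounds shown here, this does not show that the step carries over to another core, since the only other example of the exchange, on the five-membered aromatic ring with 2 nitrogen in compound 1 and compound 2, sits in a different place and cannot be read because both of its ends are limits and not numbers: the limit of < 2000 nM in this assay, at which 2 of the 4 values shown sit. The series therefore offers a single readable step on a single core, and neither its size nor its direction can be assigned to the core of compound 1.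

The compounds shown leave open how a fluoro, methyl or trifluoromethyl group would read in the same place on the core of compound 3, and so whether the step from bromo to chloro belongs to a wider trend. They also leave open whether the same exchange would matter at the other bromo group, or how an amide in place of the carboxylic acid would behave.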